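This account rests on a few compounds, and the source may have more. Where it says the series, first, only, none or still open, it means among the compounds named here.

Of the compounds shown here, two have been measured in a functional assay on the whole organism (MCF7 cells, Mus musculus) for inhibition, with MCF7 (Homo sapiens) as the target; a higher number here means a weaker inhibitor, a lower number a stronger inhibitor. Compound 1, `C=C/C=C\[C@H](C)[C@H](OC(N)=O)[C@@H](C)[C@H](O)[C@@H](C)C/C(C)=C\[C@H](C)[C@@H](O)[C@@H](C)/C=C\[C@@H](O)C[C@@H]1OC(=O)C=C[C@H]1C`, gives 2.1 nM, the lowest number of the two. Compound 2, `C=C/C=C\[C@H](C)[C@H](OC(N)=O)[C@@H](C)[C@H](O)[C@@H](C)C/C=C\[C@H](C)[C@@H](O)[C@@H](C)/C=C\[C@@H](O)C[C@@H]1OC(=O)[C@H](C)[C@@H](O)[C@H]1C`, gives 46 nM in this assay, a gap that lies beyond the usual scatter, so compound 1 is the stronger inhibitor of the pair. Compound 3, `C=C/C=C\[C@H](C)[C@H](OC(N)=O)[C@@H](C)[C@H](O)[C@@H](C)C/C(C)=C\[C@H](C)[C@@H](O)[C@@H](C)/C=C\[C@@H](O)C[C@@H]1OC(=O)C(C)=C[C@H]1C`, is the next compound to be tested. It differs from compound 1 in one place: methyl in place of hydrogen on a double-bonded ring carbon. Going by the values given here, no pair of measured compounds differs by this single change, so no measured step guides the expectation. A single methyl at that ring position is expected to leave the potency of compound 1 largely in place, giving an estimated step of a 1.7-fold higher number from compound 1 to compound 3 (0.22 log units; within the scatter) that stays within or only slightly beyond the scatter. Compound 3 is therefore expected to give about 3.5 nM in this assay, between 1 nM and 12 nM.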

Compound 3, half-maximal inhibitory concentration: 5.6 nM
Estimate against measurement, compound 3: 1.6-fold (0.20 log units) below; low and high end bracket the measured number.
By their numbers in this assay, from the lowest: compound 1; then compound 3; then compound 2.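

Methyl in place of hydrogen on a double-bonded ring carbon gives the first measured step at this position: in this assay, the change produces a 2.7-fold higher number from compound 1 to compound 3 (0.43 log units; beyond the scatter) and is modest in size. The position therefore accepts this single added carbon with a real but limited loss, and compound 3 remains a nanomolar inhibitor at 5.6 nM, while the hydrogen of compound 1 gives the lower number of this pair. Nothing on hand accounts for the size of this step.

The compounds shown leave open whether an ethyl group, a longer chain, an amine or a carboxylic acid on this ring carbon would cost more than methyl. On these data alone, it also remains open whether the methyl step would keep its size alongside changes elsewhere on the core.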